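Chloro to nitro on a fused ring: amylase inhibitors compared

A few compounds are considered here, and "the series" means these few. Any claim that something is new, unique, unknown or untested is made for them only; others in the source may bear on it.

Of the compounds shown here, three have been measured in an assay for inhibition of Alpha amylase (Homo sapiens), with a stated time of 10 min; on this read-out higher numbers stand for weaker inhibition and lower numbers for stronger inhibition. Compound 1 `COc1cc(-c2nc3cc(Cl)ccc3[nH]2)cc(I)c1O` gives 1610 nM. Compound 2 `COc1ccc(Br)c(-c2nc3cc(Cl)ccc3[nH]2)c1O` gives 2210 nM, and compound 3 `COc1ccc(Br)c(-c2nc3cc([N+](=O)[O-])ccc3[nH]2)c1O` gives 2290 nM. The difference between the core of compound 1 and the core of compound 2 is not broken down here; their two values lie within the scatter of each other.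

Compound 3 arises from compound 2 by one change, (nitro in place of chloro on an aromatic carbon), and this change made a 1.0-fold higher number from compound 2 to compound 3 (0.02 log units; within the scatter). Compound 4 `COc1cc(-c2nc3cc([N+](=O)[O-])ccc3[nH]2)cc(I)c1O`, not yet measured, arises from compound 1 by the same change, (nitro in place of chloro on an aromatic carbon), at a place described in the same words.

Because the change from compound 2 to compound 3 made a 1.0-fold higher number from compound 2 to compound 3 (0.02 log units; within the scatter), the step from compound 1 to compound 4 in this assay is expected to be about a 1.1-fold higher number from compound 1 to compound 4 (0.02 log units; within the scatter). On that basis compound 4 is estimated to give roughly 1700 nM, with a plausible range from 900 nM to 3300 nM. This expectation rests on a single measured instance of the change and should be read accordingly.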

Compound 4, half-maximal inhibitory concentration: 1720 nM
Beside the measured number, compound 4's estimate is 1.0-fold (0.01 log units) below it; the range from low to high includes it.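

In this assay, putting nitro in place of chloro on the core of compound 1 made a 1.1-fold higher number from compound 1 to compound 4 (0.03 log units; within the scatter), so this step, like the earlier one, stays within the usual scatter. Set beside the earlier step, the change reads alike on the two cores: the same change on two cores in this assay, a 1.0-fold higher number (0.02 log units; within the scatter) from compound 2 to compound 3 and a 1.1-fold higher number (0.03 log units; within the scatter) from compound 1 to compound 4, 1.0-fold (0.01 log units) apart, within the scatter of two such steps This shows that in these two matched pairs the exchange of chloro for nitro leaves the number indistinguishable from that of its parent, but it rests on only two cores and one pair of groups, and it does not show that the exchange would be equally silent on any other core in the series, nor does it say why the numbers hold.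

The compounds shown leave open whether an amine or a carboxylic acid on that same aromatic carbon would also stay within the scatter. They also leave open whether the exchange would read the same on a core carrying a longer chain in place of the methoxy group.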